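The compounds below may be only part of what the source reports. "The series", "measured", "known", "first", "only" and "open" are said of these compounds alone.

For the measured compounds named here, compound 2 `CCN(CC)CC(=O)N1N=C(C)CC1c1ccccc1OC(C)=O` gives 51200 nM in a functional assay on PC-3 cells (Homo sapiens) for cytotoxicity, read by MTT assay, with a stated time of 48 h (a higher number here means a weaker inhibitor, a lower number a stronger inhibitor), the highest of the two numbers so far. Compound 1 `CCN(CC)CC(=O)N1N=C(C)CC1c1ccccc1O` gives 25900 nM, and the step of a 2.0-fold higher number from compound 1 to compound 2 (0.30 log units; within the scatter) lies within the scatter, so the two compounds cannot be set apart on these numbers. Compound 3 `CC(=O)Oc1ccccc1C1CC(C)=NN1C(=O)CN1CCC(C(C)=O)CC1` has not yet been tested in this assay. It differs from compound 2 in that (4-acetylpiperidin-1-yl in place of diethylamino on a saturated chain carbon bound to a carbonyl carbon). Going by the values given here, no measured step bears on this change: the only step seen so far, from compound 1 to compound 2, concerns the oxygen on the aromatic ring and leaves the amine untouched, so there is no measured basis for a direction or a size. The expectation is therefore that compound 3 lands close to compound 2, with no step beyond the scatter, which means an expected step of a 1.0-fold lower number from compound 2 to compound 3 (0.01 log units; within the scatter). Compound 3 is accordingly estimated at 50000 nM, within a range of 15000 nM to 150000 nM.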

Compound 3, half-maximal inhibitory concentration: 6800 nM
The estimate for compound 3 lay 7.4-fold (0.87 log units) above the measured number; the whole stated range lies above it.
By their numbers in this assay, from the lowest: compound 3; then compounds 1 and 2 (each within the scatter of the next).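

The amine on the saturated chain carbon bound to a carbonyl carbon turns out to be a place where the read-out moves: in this assay, 4-acetylpiperidin-1-yl in place of diethylamino gives a 7.5-fold lower number from compound 2 to compound 3 (0.88 log units; beyond the scatter), whereas the earlier change on the oxygen on the aromatic ring stayed within the scatter. The entering group differs in several ways at once, bringing a six-membered non-aromatic ring with 1 hetero atom and an acetyl carbonyl, so the step cannot be assigned to either part. Nothing measured here accounts for the step.

The compounds shown do not separate the ring from the acetyl group; a plain piperidin-1-yl on the same carbon would bear on that. Also open, from the compounds shown here alone, is whether the step holds when the aromatic oxygen carries hydrogen, as in compound 1, rather than acetyl.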